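Benzyl replaces dimethylaminoethenyl on the piperazine of compound 2

The compounds below may be only part of what the source reports. "The series", "measured", "known", "first", "only" and "open" are said of these compounds alone.

Compound 1 `CN1CCN(CC(=O)Nc2ccc(-c3nc(-c4ccccc4)c(-c4ccccc4)n3C)cc2)CC1`: 18.8%
Compound 2 `CN(C)/C=C/N1CCN(CC(=O)Nc2ccc(-c3nc(-c4ccccc4)c(-c4ccccc4)n3C)cc2)CC1`: 3.1%

In a functional assay on HT-29 cells (Homo sapiens) for cytotoxicity, read by MTT assay, with a stated time of 24 h, tested at 0.64 ug/mL (a higher number here means a stronger effect of the compound at the concentration tested, a lower number a weaker effect), compound 2 gives the lowest of the two numbers, with compound 1 the nearer one. Compound 3 `Cn1c(-c2ccc(NC(=O)CN3CCN(Cc4ccccc4)CC3)cc2)nc(-c2ccccc2)c1-c1ccccc1` differs from compound 2 by benzyl in place of 2-(dimethylamino)ethenyl on an amine nitrogen in a ring. Among the compounds with values here, the only measured step at this position, a number 15.7 percentage points lower from compound 1 to compound 2 (beyond the scatter), shows the read-out is sensitive there, but neither group matches benzyl. The step is therefore expected to be a number 6.9 percentage points higher from compound 2 to compound 3 (within the scatter), most likely upward but uncertain. Compound 3 is estimated at 10%, with a range from 0% to 28%.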

Compound 3, a percentage reported as activity, at one concentration (the size of the read-out at that concentration, not a potency): 15.5%
Compound 3: the middle estimate sits 5.5 percentage points below what was measured; the measured number falls inside the stated range.
By their numbers in this assay, from the lowest: compound 2; then compounds 3 and 1 (each within the scatter of the next).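

In this assay, the low read-out of compound 2 is not shared by every larger group on this amine nitrogen in a ring: benzyl gives a number 12.4 percentage points higher from compound 2 to compound 3 (beyond the scatter) on the same core. Phenyl in place of hydrogen on the methyl carbon gives a number 3.3 percentage points lower from compound 1 to compound 3 (within the scatter) and so does not separate benzyl from methyl. Among these three groups, only 2-(dimethylamino)ethenyl stands apart. Nothing available explains this difference. Open, from the compounds shown here alone, is how a hydrogen, an acetyl group or a longer alkyl chain on this nitrogen would read, and whether a substituent on the benzyl ring would shift the value.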